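Benzyloxy replaced on the carbonyl: compound 2 to compound 3

A few compounds are considered here, and "the series" means these few. Any claim that something is new, unique, unknown or untested is made for them only; others in the source may bear on it.

Values in a functional assay on Shh Light II cells (Mus musculus) for inhibition, read by a luciferase reporter; on this read-out higher numbers stand for weaker inhibition and lower numbers for stronger inhibition:
Compound 1 `O=C(Nc1ncccc1Cl)N1CCC(c2nc(-c3ccc4ccccc4n3)no2)CC1`: 2800 nM
Compound 2 `O=C(OCc1ccccc1)N1CCC(c2nc(-c3ccc4ccccc4n3)no2)CC1`: > 2500 nM (a limit, not a number)

Compound 2 stands at the limit of > 2500 nM in this assay, at which 1 of the 2 values shown sits, and so has no number of its own.

Compound 3 `O=C(NC1CCOCC1)N1CCC(c2nc(-c3ccc4ccccc4n3)no2)CC1` carries (oxan-4-yl)amino in place of benzyloxy on a carbonyl carbon.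

For the measured compounds named here, the one measured step that bears on this change is a step that the limit leaves unreadable from compound 1 to compound 2, and it gives no size to carry over. Compound 3 shares an amino group on that carbonyl carbon with compound 1, which gives 2800 nM, so a result of similar size is expected. No firm direction can be expected from the limit alone. In this assay the expected step is a step that the limit leaves unreadable from compound 2 to compound 3. For compound 3 the estimate is 4000 nM, with an expected range of 1500 nM to 10000 nM.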

Compound 3, half-maximal inhibitory concentration: 480 nM
Beside the measured number, compound 3's estimate is 8.3-fold (0.92 log units) above it; the measured number lies below the stated range.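

In this assay, (oxan-4-yl)amino on the carbonyl carbon gives an at least 5.2-fold lower number from compound 2 to compound 3 (0.71 log units; beyond the scatter), and oxan-4-yl in place of 3-chloropyridin-2-yl on the amide-type nitrogen gives a 5.8-fold lower number from compound 1 to compound 3 (0.77 log units; beyond the scatter). The group on this carbonyl carbon therefore moves the number beyond the scatter, and an amino group there does not settle the outcome alone: compound 1 and compound 3 both carry one, and only the non-aromatic ring of compound 3 goes with the lower number. Compound 2 has a limit and not a number, so the step from compound 1 to compound 2 cannot be read: the limit of > 2500 nM in this assay, at which 1 of the 3 values shown sits.

The compounds shown do not separate the oxygen of oxan-4-yl from the non-aromatic ring as such; a cyclohexylamino or piperidin-4-ylamino group would bear on that. They also leave open what the amide hydrogen contributes, which a methyl(oxan-4-yl)amino group would address.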